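From Allyloxy to Hexyloxy: Expecting a Modest Gain

The compounds below may be only part of what the source reports. "The series", "measured", "known", "first", "only" and "open" are said of these compounds alone.

Compound 1 `C=CCOc1ccccc1Cc1cnc(N)nc1N` carries an allyloxy group on an aromatic carbon of the shared core. In an assay for inhibition of Dihydrofolate reductase (Gallus gallus) (on this read-out higher numbers stand for weaker inhibition and lower numbers for stronger inhibition), compound 1 gives 21400 nM, the highest of the three numbers recorded so far. Compound 2 `Nc1ncc(Cc2ccccc2Br)c(N)n1`, with bromo in place of allyloxy, gives 12300 nM, a change of a 1.7-fold lower number from compound 1 to compound 2 (0.24 log units; within the scatter). Compound 3 `Nc1ncc(Cc2ccccc2OCc2ccccc2)c(N)n1`, with phenyl in place of vinyl on a saturated chain carbon bound to an oxygen on an aromatic ring, gives 9120 nM, a change of a 2.3-fold lower number from compound 1 to compound 3 (0.37 log units; beyond the scatter).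

Compound 4 `CCCCCCOc1ccccc1Cc1cnc(N)nc1N` differs from compound 1 by pentyl in place of vinyl on a saturated chain carbon bound to an oxygen on an aromatic ring. The step from compound 1 to compound 3 is the one that bears on this change, since it also replaces the vinyl at the same place and lowered the number modestly; the step to compound 2 alters a different part of the molecule. Pentyl is not phenyl, so the guide is loose, but a small lowering, or nothing beyond the scatter, is expected. For compound 4 the expected step is a 1.9-fold lower number from compound 1 to compound 4 (0.29 log units; within the scatter). Compound 4 is estimated at 11000 nM, with a range from 4000 nM to 30000 nM.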

Compound 4, inhibition constant: 7940 nM
Beside the measured number, compound 4's estimate is 1.4-fold (0.14 log units) above it; the measured number falls inside the stated range.
By their numbers in this assay, from the lowest: compounds 4, 3, 2 and 1 (each within the scatter of the next, the first and the last beyond it).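

In this assay, the change from allyloxy to hexyloxy gives a 2.7-fold lower number from compound 1 to compound 4 (0.43 log units; beyond the scatter) and shows that, on this saturated chain carbon, a longer saturated chain can replace the vinyl end without the number rising. The pentyl and phenyl ends cannot be told apart here, with a 1.1-fold lower number from compound 3 to compound 4 (0.06 log units; within the scatter) within the scatter, and the same holds for hexyloxy and bromo on the aromatic carbon, with a 1.5-fold lower number from compound 2 to compound 4 (0.19 log units; within the scatter) also within the scatter. No measurement is available to explain why the longer chain lowers the number relative to allyloxy.

As far as these compounds go, it remains open whether a longer chain such as octyloxy would lower the number further, or how an amine or a carboxylic acid at the chain end would read. With a single saturated chain shown, chain length cannot be separated from the loss of the double bond.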